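A Pyridine Carbonyl Replaces the Difluorophenyl Carbonyl

The source may hold more compounds than are shown below. What is called first, only, known or untested is meant among the compounds shown, and "the series" means these compounds.

Compound 1 `CC(C)NC(=O)[C@H]1CC[C@@H](n2/c(=N/C(=O)c3ccc(F)c(F)c3)[nH]c3ccc(CN4CCC(C(C)(C)O)CC4)cc32)CC1` was examined in an in vitro ADME assay on microsomes from liver (Rattus norvegicus) for metabolic stability (on this read-out lower numbers stand for slow clearance and higher numbers for fast clearance), where compound 1 gives 19 mL.min-1.g-1. Among the three compounds measured in this assay, compound 1 shows the lowest number. Compound 2 `CC(C)NC(=O)[C@H]1CC[C@@H](n2/c(=N/C(=O)c3ccc(F)cc3)[nH]c3ccc(CN4CCCCC4)cc32)CC1` gives 451 mL.min-1.g-1 in this assay, a value that lies beyond the scatter above that of compound 1. Compound 3 `CCN(CC)C(=O)[C@H]1CC[C@@H](n2/c(=N/C(=O)c3ccccc3)[nH]c3ccc(CN4CCCCC4)cc32)CC1` gives 682 mL.min-1.g-1 in this assay, the highest of the three and also beyond the scatter relative to compound 1. Compounds 2 and 3 each differ from compound 1 in more than one place, so their values show only that both lie well above compound 1.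

Compound 4 `CC(C)NC(=O)[C@H]1CC[C@@H](n2/c(=N/C(=O)c3cccnc3)[nH]c3ccc(CN4CCC(C(C)(C)O)CC4)cc32)CC1` has not yet been measured. It differs from compound 1 in one place: pyridin-3-yl in place of 3,4-difluorophenyl on a carbonyl carbon. Among the compounds with values here, no pair of measured compounds carries this same change, so nothing measured here fixes its size. The step from compound 1 to compound 4 is expected to be a 1.5-fold higher number from compound 1 to compound 4 (0.17 log units; within the scatter), that is, a small rise that stays within the usual scatter of this assay or only slightly beyond it. On that basis compound 4 is estimated to give 28 mL.min-1.g-1 in this assay, with a range from 9 mL.min-1.g-1 to 90 mL.min-1.g-1.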

Compound 4, intrinsic clearance in microsomes: < 14 mL.min-1.g-1
Compound 4 gave a limit, no number; the forecaster's own chance of this, stated with the estimate: 10%; at least 2.0-fold (0.30 log units) between middle value and limit.
By their numbers in this assay, from the lowest: compound 1; then compounds 2 and 3 (each within the scatter of the next). At a limit, below all of these: compound 4.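

Within the data shown here, compound 1 and compound 4 form the first pair here that differs in one place only, so the group on the carbonyl carbon can now be read on its own: pyridin-3-yl in place of 3,4-difluorophenyl gives an at least 1.3-fold lower number from compound 1 to compound 4 (0.13 log units; that floor lies within the scatter). In this assay compound 4 gives < 14 mL.min-1.g-1, which is a limit of the assay and not a number. The step is thus a floor and not a size, and since that floor lies within the scatter, the pair shows that no rise appeared with this change, not that the number fell beyond the scatter: the limit of < 14 mL.min-1.g-1 in this assay, at which 1 of the 4 values shown sits.

The compounds shown leave open how far compound 4 truly lies from compound 1, and whether pyridin-4-yl or pyrimidin-5-yl on the same carbonyl carbon would read as pyridin-3-yl does. Also open, going by these compounds, is whether the change would read the same with a tert-butyl group in place of the isopropyl group on the other amide.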